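Adding chloro to compound 2: expected effect on cytotoxicity

The source may hold more compounds than are shown below. What is called first, only, known or untested is meant among the compounds shown, and "the series" means these compounds.

In a toxicity assay on HeLa cells (Homo sapiens) for cytotoxicity, read by MTT assay, with a stated time of 24 h (a higher number here means a weaker inhibitor, a lower number a stronger inhibitor), compound 1 `CCN(CC)C(=S)SCC(O)Cn1c([N+](=O)[O-])cnc1C` reads 2460000 nM as a measured number. Compound 2 `Cc1ncc([N+](=O)[O-])n1CC(O)CN1CCN(c2ccccc2)CC1` reads > 5000000 nM in this assay and this is a limit of the assay, not a number. The standing of compound 2 is therefore known only as that limit. Compound 3 `Cc1ncc([N+](=O)[O-])n1CC(O)CN1CCN(c2cccc(Cl)c2)CC1` differs from compound 2 by one change: chloro in place of hydrogen on an aromatic carbon which amounts to phenyl to 3-chlorophenyl, chloro in place of hydrogen on an aromatic carbon. For the measured compounds named here, no measured pair shows this change. A modest move towards stronger inhibition is expected, perhaps none beyond the scatter, and compound 3 may also stop at the limit. The expectation rests on compound 2 with its limit > 5000000 nM as the starting point. The estimated at least 1.2-fold lower number from compound 2 to compound 3 (0.09 log units; that floor lies within the scatter) is small in size. In this assay compound 3 is expected at 4000000 nM within an estimated range of 1500000 nM to 8000000 nM as the working figure.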

Compound 3, half-maximal inhibitory concentration: 1440000 nM
Compound 3: middle estimate off by 2.8-fold (0.44 log units), on the high side; the measured number lies below the stated range.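

In this assay, for the compounds shown here, the phenyl to 3-chlorophenyl change gives an at least 3.4-fold lower number from compound 2 to compound 3 (0.54 log units; beyond the scatter), the first reading for a substituent on this aromatic ring, here meta to a large group. Compound 2 reads > 5000000 nM, which is a limit of the assay and not a number. The step is therefore a floor and its full size stays unknown, because compound 2 sits at that limit: the limit of > 5000000 nM in this assay, at which 1 of the 3 values shown sits.

The compounds shown leave open whether a methoxy group or a fluoro group in the same place would give a step of similar size, or whether this step is particular to chloro. They also leave open whether chloro elsewhere on this ring would match it, since a single substituted compound defines no trend across the series.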